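A few compounds are considered here, and "the series" means these few. Any claim that something is new, unique, unknown or untested is made for them only; others in the source may bear on it.

Measured in a functional assay on MDA-MB-435 cells (Homo sapiens) for inhibition; a higher number here means a weaker inhibitor, a lower number a stronger inhibitor:
Compound 1 `O=C(/C=C/c1ccc(I)cc1)c1ccc(O)cc1`: 4500 nM
Compound 2 `O=C(/C=C/c1ccc(F)c(F)c1)c1ccc(B(O)O)cc1`: 8800 nM

Compound 1 and compound 2 lie within the usual scatter of each other, so these numbers do not rank them. Compound 3 `O=C(/C=C/c1ccc(I)cc1)c1ccc(B(O)O)cc1` alters compound 1 at one place, on an aromatic carbon para to a large group: the hydroxy leaves and a group of boron and oxygen enters (a group of 3 heavy atoms (1 boron, 2 oxygen; no ring) in place of one oxygen atom, on an aromatic carbon). Going by the values given here, no measured pair shows this change, so no step beyond the scatter is expected in either direction, and the estimated move is a 1.1-fold higher number from compound 1 to compound 3 (0.05 log units; within the scatter). Compound 3 is expected at 5000 nM, within an estimated range of 1500 nM to 15000 nM.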

Compound 3, half-maximal inhibitory concentration: 10000 nM
Estimate against measurement, compound 3: 2.0-fold (0.30 log units) below, within the range that was stated.
By their numbers in this assay, from the lowest: compounds 1, 2 and 3 (each within the scatter of the next, the first and the last beyond it).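

On the aromatic carbon para to a large group, replacing the hydroxy with the group of boron and oxygen gives a 2.2-fold higher number from compound 1 to compound 3 (0.35 log units; beyond the scatter) in this assay. Going by these compounds alone, this is the first step beyond the scatter, though a modest one, and in this pair the hydroxy gives the stronger inhibitor. Nothing available explains this step.

On these data alone, whether an amine or a carboxylic acid at this carbon would give a number nearer that of compound 1 or that of compound 3 remains open. So does whether the same replacement has a similar effect on the core of compound 2.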